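Amide substituent series: methoxy to methyl

A few compounds are considered here, and "the series" means these few. Any claim that something is new, unique, unknown or untested is made for them only; others in the source may bear on it.

Compound 1 `O=C(Nc1cccc(-c2oc3cc(-c4ccc(F)cc4)ccc3c(=O)c2O)c1)c1ccccc1F` gives 7240 nM in a functional assay on MDA-MB-231 cells (Homo sapiens) for antiproliferative activity, read by CCK-8 assay, with a stated time of 72 h; a higher number here means a weaker inhibitor, a lower number a stronger inhibitor.
Compound 2 `O=C(Nc1cccc(-c2oc3cc(-c4ccc(F)cc4)ccc3c(=O)c2O)c1)c1ccc(Cl)cc1` gives 12800 nM.
Compound 3 `COc1ccccc1C(=O)Nc1cccc(-c2oc3cc(-c4ccc(F)cc4)ccc3c(=O)c2O)c1` gives 5110 nM.

Compound 3 has the lowest number of the three in this assay; its gap to compound 1 is within the scatter, its gap to compound 2 is beyond it, as a 2.5-fold lower number from compound 2 to compound 3 (0.40 log units; beyond the scatter) shows, so compound 3 cannot be set apart from compound 1. The change to compound 4 `Cc1ccccc1C(=O)Nc1cccc(-c2oc3cc(-c4ccc(F)cc4)ccc3c(=O)c2O)c1` is methyl in place of methoxy on an aromatic carbon. Among the measured compounds shown here, one measured step bears directly on it: a 1.4-fold lower number from compound 1 to compound 3 (0.15 log units; within the scatter), the only other exchange of a small group at that same aromatic carbon, and it stayed within the scatter. The two steps that exchange the whole aryl group, a 1.8-fold higher number from compound 1 to compound 2 (0.25 log units; within the scatter) and a 2.5-fold lower number from compound 2 to compound 3 (0.40 log units; beyond the scatter), are larger, but they change a different group altogether and say little about a methyl at this place. With one small group replaced by another where the measured exchange moved the number little, no step beyond the scatter is expected in this assay, in either direction. The expected step is a 1.2-fold higher number from compound 3 to compound 4 (0.07 log units; within the scatter). Compound 4 is therefore estimated at 6000 nM, with a range of 2500 nM to 14000 nM.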

Compound 4, half-maximal inhibitory concentration: 4910 nM
Estimate against measurement, compound 4: 1.2-fold (0.09 log units) above, and the stated range covers the measured number.
By their numbers in this assay, from the lowest: compounds 4, 3, 1 and 2 (each within the scatter of the next, the first and the last beyond it).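

In this assay, the methoxy-to-methyl exchange on this aromatic carbon, ortho to a large group, gives a 1.0-fold lower number from compound 3 to compound 4 (0.02 log units; within the scatter), so the hydrogen-bond acceptor that leaves with the methoxy has no readable effect on the number here. Fluoro and methyl at this carbon also stay within the scatter, at a 1.5-fold lower number from compound 1 to compound 4 (0.17 log units; within the scatter), which puts the three small groups shown at this place on one level in this assay. The 2-methylphenyl amide joins the 2-methoxyphenyl amide in lying clear of the 4-chlorophenyl amide, at a 2.6-fold lower number from compound 2 to compound 4 (0.42 log units; beyond the scatter), though the 2-fluorophenyl amide goes against any general split of this kind, with a 1.8-fold higher number from compound 1 to compound 2 (0.25 log units; within the scatter) staying within the scatter, and no measurement at hand explains any of these results.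

The compounds shown leave open whether an amine, a carboxylic acid or a longer chain such as ethoxy at this carbon would move the number beyond the scatter. Also open, going by these compounds, is whether the gap to compound 2 belongs to the chloro group itself or to its place on the ring, a question a 2-chlorophenyl amide would address.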